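This account rests on a few compounds, and the source may have more. Where it says the series, first, only, none or still open, it means among the compounds named here.

Compound 1 is `c1ccc2c(c1)CCCC2CCCN1CCN(C2CCCCC2)CC1`. In an assay for binding affinity to Adrenergic receptor alpha-1 (Rattus norvegicus) (on this read-out higher numbers stand for weaker inhibition and lower numbers for stronger inhibition), compound 1 gives only a limit, > 7500 nM. Compound 2 is `COc1ccc2c(c1)C(CCCN1CCN(C3CCCCC3)CC1)CCC2`. In this assay compound 2 gives only a limit, > 7500 nM.

Compound 1 thus stands at a limit, not at a number, and both values shown sit there (the limit of > 7500 nM in this assay, at which 2 of the 2 values shown sit). Compound 3 is `Oc1ccc2c(c1)CCCC2CCCN1CCN(C2CCCCC2)CC1`; it differs from compound 1 by hydroxy in place of hydrogen on an aromatic carbon. Going by the values given here, the one measured step at this ring, a step that the two limits leave unreadable from compound 1 to compound 2, reads no size, since both ends rest at the limit (the limit of > 7500 nM in this assay, at which 2 of the 2 values shown sit). Compound 3 is therefore expected to stay at the limit as well, estimated at 12000 nM within 3000 nM to 40000 nM, a step that the limit leaves unreadable from compound 1 to compound 3.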

Compound 3, inhibition constant: > 7500 nM
Compound 3 was reported as a limit; the forecaster's own chance of this, stated with the estimate: 80%; the middle value is on the limit's open side.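

No step can be read from compound 1 to compound 3, because both rest at a limit in this assay: the limit of > 7500 nM in this assay, at which 3 of the 3 values shown sit.

The compounds shown leave open how strongly any of the three binds and whether hydroxy or methoxy in place of hydrogen changes that binding at all.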